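The source may hold more compounds than are shown below. What is called first, only, known or untested is meant among the compounds shown, and "the series" means these compounds.

Within the data shown here, in a functional assay for inhibition, with Homo sapiens as the target (a higher number here means weaker binding, a lower number tighter binding), compound 3 `CC(C)(Oc1ccccc1[N+](=O)[O-])C1OCC(C/C=C\CCC(=O)O)C(c2cccnc2)O1` gives 11.2 nM, the lowest of the three numbers so far, against compound 2 `CC(C)(Oc1ccccc1O)C1OCC(C/C=C\CCC(=O)O)C(c2cccnc2)O1` at 95.5 nM and compound 1 `Cc1ccc(OC(C)(C)C2OCC(C/C=C\CCC(=O)O)C(c3cccnc3)O2)cc1` at 631 nM. Compound 4 `CC(C)(Oc1ccc(F)cc1[N+](=O)[O-])C1OCC(C/C=C\CCC(=O)O)C(c2cccnc2)O1` differs from compound 3 by fluoro in place of hydrogen on an aromatic carbon. The measured steps all alter groups on that aromatic ring: a 6.6-fold lower number from compound 1 to compound 2 (0.82 log units; beyond the scatter), a 56-fold lower number from compound 1 to compound 3 (1.75 log units; beyond the scatter) and an 8.5-fold lower number from compound 2 to compound 3 (0.93 log units; beyond the scatter). All three lie beyond the scatter, but none introduces fluoro, so none gives a direct size for this change. No shift beyond the scatter is therefore expected in this assay, and no direction is favoured. The expected step is a 1.0-fold lower number from compound 3 to compound 4 (0.01 log units; within the scatter). The estimate for compound 4 is 11 nM, with an expected range of 4 nM to 30 nM.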

Compound 4, dissociation constant: 2.51 nM
Estimate against measurement, compound 4: 4.4-fold (0.64 log units) above, outside the stated range (below it).
By their numbers in this assay, from the lowest: compound 4; then compound 3; then compound 2; then compound 1.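

In this assay, fluoro on the aromatic carbon meta to a nitro group and para to a large group gives a 4.5-fold lower number from compound 3 to compound 4 (0.65 log units; beyond the scatter), so this carbon of the 2-nitrophenyl group still affects the number once the nitro group is present. The wider changes, a 38-fold lower number from compound 2 to compound 4 (1.58 log units; beyond the scatter) and a 250-fold lower number from compound 1 to compound 4 (2.40 log units; beyond the scatter), leave compound 4 lowest of the four. Nothing measured here bears on why fluoro has this effect. On these data alone, whether chloro or methoxy on the same carbon would match fluoro remains open. So does whether fluoro would lower the number without the nitro group.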